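Capping the hydroxy of compound 3 with a carboxypropyl chain

The source may hold more compounds than are shown below. What is called first, only, known or untested is meant among the compounds shown, and "the series" means these compounds.

In a functional assay on K562 cells (Homo sapiens) for cytotoxicity, read by trypan blue exclusion, with a stated time of 96 h (a lower number here means a stronger inhibitor, a higher number a weaker inhibitor), compound 3 (`COc1ccc(CS(=O)(=O)/C=C/c2c(OC)cc(O)cc2OC)cc1N`) gives 300 nM, the highest of three numbers. Compound 1 (`COc1ccc(CS(=O)(=O)/C=C/c2c(OC)cccc2OC)cc1N`) gives 50 nM, and compound 2 (`COc1cc(OC)c(/C=C/S(=O)(=O)Cc2ccc(OC)c(N)c2)c(OC)c1`) gives 2.5 nM. Adding the hydroxy group meant a 6.0-fold higher number from compound 1 to compound 3 (0.78 log units; beyond the scatter), and removing the methyl from an oxygen meant a 120-fold higher number from compound 2 to compound 3 (2.08 log units; beyond the scatter). Compound 4 (`COc1ccc(CS(=O)(=O)/C=C/c2c(OC)cc(OCCCC(=O)O)cc2OC)cc1N`) has 3-carboxypropyl in place of hydrogen on an oxygen on an aromatic ring. Going by the values given here, that oxygen is capped again, as in compound 2, but no measured step tests a chain like this one. Only part of a 120-fold higher number from compound 2 to compound 3 (2.08 log units; beyond the scatter) is therefore expected to be reversed. The expected modest change in this assay is a 3.0-fold lower number from compound 3 to compound 4 (0.48 log units; beyond the scatter). Compound 4 is estimated at 100 nM, with an expected range of 15 nM to 600 nM.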

Compound 4, half-maximal inhibitory concentration: 20000 nM
Estimate against measurement, compound 4: 200-fold (2.30 log units) below, and the stated range ends below it.
By their numbers in this assay, from the lowest: compound 2; then compound 1; then compound 3; then compound 4.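

In this assay, capping this oxygen does not by itself bring the number back down: the 3-carboxypropyl group gives a 67-fold higher number from compound 3 to compound 4 (1.82 log units; beyond the scatter) and so moves further in the direction that losing the methyl had already taken. What sits on the oxygen therefore matters greatly, with an 8000-fold higher number from compound 2 to compound 4 (3.90 log units; beyond the scatter) separating the 3-carboxypropyl group from the methyl, and a 400-fold higher number from compound 1 to compound 4 (2.60 log units; beyond the scatter) showing that the 3-carboxypropoxy group also stands far above plain hydrogen on the aromatic carbon. Nothing available explains this rise. Still open, as far as these compounds go, is whether the carboxylic acid or the chain carries the effect, which a methyl ester of the same acid or a plain butyl chain on this oxygen would help separate.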